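Anilide substituent variation and growth inhibition in cervical cancer cells

The source may report more compounds than this note shows. Statements on the series, on what has been measured and on what is new or still open speak of the compounds shown alone.

Measured compounds:
compound 1 `CN(C)C(=O)c1cc2cnc(Nc3ccc(NC(=O)C4(C(=O)Nc5ccc(F)cc5)CC4)cc3)nc2n1C1CCCC1`: 36.5%
compound 2 `CN(C)C(=O)c1cc2cnc(Nc3ccc(NC(=O)C4(C(=O)Nc5ccc(Br)cc5)CC4)cc3)nc2n1C1CCCC1`: 23.2%
compound 3 `CN(C)C(=O)c1cc2cnc(Nc3ccc(NC(=O)C4(C(=O)Nc5ccc(O)cc5)CC4)cc3)nc2n1C1CCCC1`: 69.5%

In a functional assay on SiHa cells (Homo sapiens) for inhibition, read by CCK-8 assay, with a stated time of 72 h, tested at 1 uM (a lower number here means less inhibition of growth, a higher number more inhibition of growth at the concentration tested), compound 1 stands second highest of the three numbers. The measured steps are a number 13.3 percentage points lower from compound 1 to compound 2 (beyond the scatter), a number 33 percentage points higher from compound 1 to compound 3 (beyond the scatter) and a number 46.3 percentage points higher from compound 2 to compound 3 (beyond the scatter); both steps away from fluoro lie beyond the scatter, in opposite directions.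

Compound 4 `CN(C)C(=O)c1cc2cnc(Nc3ccc(NC(=O)C4(C(=O)Nc5ccccc5)CC4)cc3)nc2n1C1CCCC1` differs from compound 1 by hydrogen in place of fluoro on an aromatic carbon. Going by the values given here, no measured step exchanges a substituent for hydrogen at this position, so the bromo and hydroxy steps show only that this assay responds strongly to what sits there, without pointing a direction. The step is therefore expected to be small, a number 2.5 percentage points lower from compound 1 to compound 4 (within the scatter), within or close to the scatter. The estimate for compound 4 is 34%, with a range from 15% to 55%.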

Compound 4, percent growth inhibition at one concentration: 58%
Beside the measured number, compound 4's estimate is 24 percentage points below it, outside the stated range (above it).
By their numbers in this assay, from the lowest: compound 2; then compound 1; then compound 4; then compound 3.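

Hydrogen is no neutral reference at this position: in this assay the loss of fluoro gives a number 21.5 percentage points higher from compound 1 to compound 4 (beyond the scatter) and the loss of bromo gives a number 34.8 percentage points higher from compound 2 to compound 4 (beyond the scatter) with both halogens thus lying under the unsubstituted phenyl. Of the groups shown, only hydroxy stays above hydrogen, the exchange reading a number 11.5 percentage points lower from compound 3 to compound 4 (beyond the scatter) and so substitution here can either lower or raise the number. Nothing at hand accounts for this order.

On these data alone, whether an amine, a methoxy group or a carboxylic acid here would follow hydroxy or the halogens stays open. So does whether chloro would fall with fluoro and bromo.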